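From thiazolyl amide to bromophenyl amide: cytotoxicity outlook

The source may hold more compounds than are shown below. What is called first, only, known or untested is meant among the compounds shown, and "the series" means these compounds.

Compound 1 `O=C(O)CCc1cccc2c1B(O)OC2`: in an ADME assay on WI-38 cells (Homo sapiens) for cytotoxicity, read by MTT assay, with a stated time of 72 h (a lower number here means a stronger inhibitor, a higher number a weaker inhibitor), compound 1 gives > 100000 nM, a limit of the assay rather than a number.
Compound 2 `O=C(CCc1cccc2c1B(O)OC2)Nc1nccs1`: in this assay compound 2 gives > 100000 nM, again a limit rather than a number.

Because both values sit at the limit of > 100000 nM in this assay, at which 2 of the 2 values shown sit, the step that the two limits leave unreadable from compound 1 to compound 2 cannot be read, and compound 2 stands only at a limit. Compound 3 `O=C(CCc1cccc2c1B(O)OC2)Nc1cccc(Br)c1` differs from compound 2 by 3-bromophenyl in place of 1,3-thiazol-2-yl on an amide-type nitrogen. Going by the values given here, no measured step bears on this change, so no particular size or direction is expected in this assay. Compound 3 is therefore estimated at 150000 nM, within 40000 nM to 600000 nM. The expected step that the limit leaves unreadable from compound 2 to compound 3 would most likely again be reported only as a limit.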

Compound 3, half-maximal inhibitory concentration: 20000 nM
Compound 3: middle estimate off by 7.5-fold (0.88 log units), on the high side; measured number outside the range, below it.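

Placing 3-bromophenyl in place of 1,3-thiazol-2-yl on the amide-type nitrogen gives an at least 5.0-fold lower number from compound 2 to compound 3 (0.69 log units; beyond the scatter) in this assay and is the only readable step here. Going by these compounds alone, it shows that the group on this nitrogen can change the cytotoxicity reading, which the earlier compounds could not show. As far as these compounds go, the true size stays open because compound 2 stands only at a limit: the limit of > 100000 nM in this assay, at which 2 of the 3 values shown sit.

From the compounds shown here alone, whether the bromine or the carbon-only ring matters remains open. A plain phenyl on the same nitrogen would separate the two.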